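The source may hold more compounds than are shown below. What is called first, only, known or untested is meant among the compounds shown, and "the series" means these compounds.

In a functional assay on DWD cells (Homo sapiens) for inhibition, read by sulforhodamine B assay (a higher number here means a weaker inhibitor of growth, a lower number a stronger inhibitor of growth), compound 1 (`Fc1ccc(-c2ccc(-c3ccc(-c4nc5ccccc5[nH]4)cc3)cc2)cc1`) gives 35600 nM and compound 2 (`Oc1cccc2[nH]c(-c3ccc(-c4ccc(-c5ccccc5)cc4)cc3)nc12`) gives 9680 nM. Compound 2 therefore has the lower of the two numbers, and the gap lies beyond the usual scatter. Compound 3 (`Oc1cccc2[nH]c(-c3ccc(-c4ccc(-c5ccc(F)cc5)cc4)cc3)nc12`) changes compound 2 in one place, phenyl to 4-fluorophenyl: fluoro in place of hydrogen on an aromatic carbon. This puts fluoro in place of hydrogen on an aromatic carbon. Among the measured compounds shown here, no measured pair shows this change alone, so no step beyond the scatter is expected in this assay. The estimated step is a 1.1-fold lower number from compound 2 to compound 3 (0.03 log units; within the scatter). For compound 3, the estimated value is 9000 nM, with a range of 4000 nM to 22000 nM.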

Compound 3, concentration for 50% growth inhibition: 22200 nM
For compound 3 the middle estimate is 2.5-fold (0.39 log units) below the measured one; measured number above the stated range.
By their numbers in this assay, from the lowest: compound 2; then compounds 3 and 1 (each within the scatter of the next).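

In this assay, fluoro in place of hydrogen, para to a large group, gives a 2.3-fold higher number from compound 2 to compound 3 (0.36 log units; beyond the scatter), a first sign that this aromatic carbon responds to a single added heavy atom. With fluoro present, a hydroxy group added to the shared core gives a 1.6-fold lower number from compound 1 to compound 3 (0.21 log units; within the scatter), so this pair shows no effect of hydroxy that stands clear of the scatter. No evidence is available on the reason for either result. From the compounds shown here alone, whether chloro, methoxy or an amine at the same carbon would behave like fluoro remains open.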